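From a bromopropyl tail to a dihydroxypropyl tail

A few compounds are considered here, and "the series" means these few. Any claim that something is new, unique, unknown or untested is made for them only; others in the source may bear on it.

Measured so far:
compound 1 `O=c1c(-c2ccc(O)cc2)coc2cc(OCCCCBr)ccc12`: 19.2%
compound 2 `O=c1c(-c2ccc(O)cc2)coc2cc(OCCCBr)ccc12`: 51.1%

In a functional assay on mitochondria (Cricetulus griseus) for inhibition of Monoamine oxidase (Homo sapiens), tested at 0.3 uM (a lower number here means a weaker effect, a higher number a stronger effect of the compound at the concentration tested), compound 2 stands highest of the two numbers, compound 1 lying lower. Within the data shown here, the only measured step, a number 31.9 percentage points higher from compound 1 to compound 2 (beyond the scatter), shortens the chain by one carbon and is large. Compound 3 `O=c1c(-c2ccc(O)cc2)coc2cc(OCC(O)CO)ccc12` differs from compound 2 by 1,2-dihydroxyethyl in place of 2-bromoethyl on a saturated chain carbon bound to an oxygen on an aromatic ring. Among the measured compounds shown here, no measured step exchanges bromine for hydroxyl groups, so that step offers no direct guide, and the expectation is loose. Compound 3 is expected to give 25%, ranging from 5% to 50%, an estimated step of a number 26.1 percentage points lower from compound 2 to compound 3 (beyond the scatter) in this assay.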

Compound 3, a percentage reported as inhibition, at one concentration (the size of the read-out at that concentration, not a potency): 33.3%
Beside the measured number, compound 3's estimate is 8.3 percentage points below it; the range from low to high includes it.
By their numbers in this assay, from the lowest: compound 1; then compound 3; then compound 2.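

In this assay, exchanging the 3-bromopropyl tail for 2,3-dihydroxypropyl gives a number 17.8 percentage points lower from compound 2 to compound 3 (beyond the scatter), so bromine is not needed for some inhibition at this position, although this tail does not match the shorter bromine-bearing one. Set against the longer bromine-bearing tail, the same change gives a number 14.1 percentage points higher from compound 1 to compound 3 (beyond the scatter), so the outcome depends on which bromine-bearing chain is the starting point. Nothing available explains this order of the three tails. Still open, on these data alone, is how an amine or a carboxylic acid at the end of this chain would compare.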